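Inversion at the chain stereocentre of a pyrrolidine ether

A few compounds are considered here, and "the series" means these few. Any claim that something is new, unique, unknown or untested is made for them only; others in the source may bear on it.

Compound 2 `CC1=C(c2cccc(O)c2)C(c2ccc(OC[C@H](C)N3CCCC3)cc2)Oc2ccc(O)cc21` is the point of departure. In a functional assay on MCF7 cells (Homo sapiens) for antiproliferative activity, read by CellTiter-Glo, with a stated time of 5 days (on this read-out higher numbers stand for weaker inhibition and lower numbers for stronger inhibition), compound 2 gives 0.2 nM, and it sits level with compound 1 `CC1=C(c2cccc(O)c2)C(c2ccc(OC[C@@H](C)N3CC[C@H](C)C3)cc2)Oc2ccc(O)cc21`, which in this assay gives 0.2 nM; the step of no change at the digits printed from compound 1 to compound 2 (within the scatter) swaps one five-membered ring amine for another without moving the number. Compound 3 `CC1=C(c2cccc(O)c2)C(c2ccc(OC[C@@H](C)N3CCCC3)cc2)Oc2ccc(O)cc21` keeps every atom and bond of compound 2; the difference is the two compounds have the same atoms and bonds; at least one stereo element is drawn with a configuration in one of them and without one in the other: 1 of 2 stereo elements differ; a stereocentre at a saturated chain carbon is drawn S in compound 2 and R in compound 3. Within the data shown here, no measured step in this set tests an inversion at that carbon, so the only bearing comes from the ring swap on the same carbon, which was flat. The author therefore expects no movement beyond the scatter, the estimated step being no change at the digits printed from compound 2 to compound 3 (within the scatter). Compound 3 is estimated in this assay at 0.2 nM, within a range from 0.07 nM to 0.6 nM.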

Compound 3, half-maximal inhibitory concentration: 0.2 nM
For compound 3 middle estimate and measured number coincide at the digits printed; the measured number falls inside the stated range.
By their numbers in this assay, from the lowest: compounds 1, 2 and 3 (each within the scatter of the next).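

Inversion at the saturated chain carbon is now tested on its own, and in this assay the step reads no change at the digits printed from compound 2 to compound 3 (within the scatter). Compound 3 also isolates the ring methyl, which the earlier step had carried within an exchange of the whole amine group: with hydrogen in place of methyl on a saturated ring carbon, the step reads no change at the digits printed from compound 1 to compound 3 (within the scatter). At this position, then, neither the drawn configuration of the chain carbon nor the ring methyl moves the number beyond the scatter, though the reading of the inversion has one qualification: the fact that one of compounds 2 and 3 is drawn with a defined configuration and the other without, at the place where they differ.

The compounds shown leave open whether this tolerance extends to other amines on the same chain carbon, such as a piperidine or a dimethylamino group. They also leave open what happens when the methyl on that chain carbon gives way to hydrogen or to an ethyl group.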